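Removing One Methoxy Group From a Desaturase Inhibitor

A few compounds are considered here, and "the series" means these few. Any claim that something is new, unique, unknown or untested is made for them only; others in the source may bear on it.

Compound 1 `Cn1c(=O)n(Cc2cc(O)c(Cl)cc2Cl)c2ccccc21` and compound 2 `COc1ccc(OC)c(N2CC(c3ccc(F)cc3)OC2=O)c1` were tested in an assay on cell membranes from liver (microsomes) for displacement of a labelled ligand from acyl-CoA (8-3)-desaturase (Rattus norvegicus), read by scintillation counting and radioligand binding, with stated times of 15 min and 150 min; a higher number here means a weaker inhibitor, a lower number a stronger inhibitor. In this assay compound 1 gives 39 nM, while compound 2 gives 13 nM. Compound 2 thus has the lower of the two numbers, and the gap to compound 1 exceeds the usual scatter of repeated measurements. The next compound, compound 3 `COc1cccc(N2CC(c3ccc(F)cc3)OC2=O)c1`, is made from compound 2 by one change: hydrogen in place of methoxy on an aromatic carbon. Within the data shown here, no measured pair in this set shows what such a change does, so the expectation rests only on the two numbers above and on the nature of the change. The step is expected to be a modest weakening, a 2.7-fold higher number from compound 2 to compound 3 (0.43 log units; beyond the scatter), likely beyond the scatter but not large. Compound 3 is estimated at 35 nM, within a range from 10 nM to 120 nM.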

Compound 3, half-maximal inhibitory concentration: 8.5 nM
For compound 3 the middle estimate is 4.1-fold (0.61 log units) above the measured one, and the stated range ends above it.
By their numbers in this assay, from the lowest: compounds 3 and 2 (each within the scatter of the next); then compound 1.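

In this assay the methoxy group on this aromatic carbon, ortho to a large group and para to a methoxy group, turns out not to be needed for binding: hydrogen in its place gives a 1.5-fold lower number from compound 2 to compound 3 (0.18 log units; within the scatter) and so the two compounds cannot be told apart. The smaller structure, with two heavy atoms and one hydrogen-bond acceptor fewer, therefore keeps the inhibition seen with the methoxy group in place. Nothing among the data shown explains why this position accepts the change.

Going by these compounds, only hydrogen and methoxy are seen at this position, so it remains open how an amine, a carboxylic acid or a longer chain such as ethoxy would fare there. Also open is what the methoxy group remaining in compound 3 contributes, since the compounds shown offer no single change at that place.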